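A few compounds are considered here, and "the series" means these few. Any claim that something is new, unique, unknown or untested is made for them only; others in the source may bear on it.

Three compounds have been measured in an assay on NIH3T3 cells with Urotensin-2 receptor (Homo sapiens) as the target; a higher number here means a larger maximal response, a lower number a smaller maximal response:

- compound 1, `COc1cccc(C(=O)OC(CCN(C)C)c2ccc(Cl)cc2)c1C`: 88%
- compound 2, `Cc1c(Cl)cccc1C(=O)OC(CCN(C)C)c1ccc(Cl)cc1`: 118%
- compound 3, `COc1cccc(C(=O)NC(CCN(C)C)c2ccc(Cl)cc2)c1C`: 179%

Compound 1 and compound 2 differ in one place, (chloro in place of methoxy on an aromatic carbon), and this gave a number 30 percentage points higher from compound 1 to compound 2 (beyond the scatter). Compound 3 has a different core from compound 1; the difference between the two cores is not broken down here. In this assay compound 3 gives the highest value of the three.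

Compound 4, `Cc1c(Cl)cccc1C(=O)NC(CCN(C)C)c1ccc(Cl)cc1`, has not yet been measured. It differs from compound 3 by chloro in place of methoxy on an aromatic carbon, the same change as from compound 1 to compound 2, which occurs two times among these compounds. Because the earlier step was a number 30 percentage points higher from compound 1 to compound 2 (beyond the scatter), a step of similar direction is expected here, estimated as a number 26 percentage points higher from compound 3 to compound 4 (beyond the scatter). For compound 4 the expected value is 205%, likely between 160% and 250%.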

Compound 4, largest response reached (reported as efficacy), in percent of the reference or control that the assay uses: 142%
The estimate for compound 4 lay 63 percentage points above the measured number; measured number outside the range, below it.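

In this assay, chloro in place of methoxy gave a number 37 percentage points lower from compound 3 to compound 4 (beyond the scatter). The same change does not carry over between these two cores, and its two steps run in opposite directions: the same change on two cores in this assay, a number 30 percentage points higher (beyond the scatter) from compound 1 to compound 2 and a number 37 percentage points lower (beyond the scatter) from compound 3 to compound 4, 67 percentage points apart, beyond the scatter of two such steps

So the outcome of this swap depends on the core it is made on, at least for these two pairs. Two pairs cannot explain the reversal, however, and they cannot predict the swap on any further core.

On these data alone, it remains open whether another group on that aromatic carbon, such as fluoro or ethoxy, would follow the rise seen on one core or the fall seen on the other. As far as these compounds go, whether a longer chain carrying the amine would change this picture also remains open.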